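Methoxy to formylamino: an expected solubility step

The source may hold more compounds than are shown below. What is called first, only, known or untested is meant among the compounds shown, and "the series" means these compounds.

Measured in a physicochemical assay for solubility, read by HPLC, with a stated time of 24 h; a higher number here means a more soluble compound, a lower number a less soluble compound:
compound 1, `CN1CCN(C[C@H]2CN(c3ccc(-n4cc(-c5ccccn5)cn4)c(F)c3)C(=O)O2)CC1`: 1690000 nM
compound 2, `O=C1CCC(=O)N1C[C@H]1CN(c2ccc(-n3cc(-c4ccccn4)cn3)c(F)c2)C(=O)O1`: 45300 nM
compound 3, `COC[C@H]1CN(c2ccc(-n3cc(-c4ccccn4)cn3)c(F)c2)C(=O)O1`: 36200 nM

Compound 3 gives the lowest of the three numbers; its nearest neighbour is compound 2, with a 1.3-fold lower number from compound 2 to compound 3 (0.10 log units; within the scatter), while compound 1 lies far off, with a 47-fold lower number from compound 1 to compound 3 (1.67 log units; beyond the scatter). Compound 4, `O=CNC[C@H]1CN(c2ccc(-n3cc(-c4ccccn4)cn3)c(F)c2)C(=O)O1`, differs from compound 3 by formylamino in place of methoxy on a saturated chain carbon bound to a saturated ring carbon. The large steps of a 37-fold lower number from compound 1 to compound 2 (1.57 log units; beyond the scatter) and a 47-fold lower number from compound 1 to compound 3 (1.67 log units; beyond the scatter) both concern the 4-methylpiperazin-1-yl group, which compound 3 and compound 4 lack. Going by the values given here, the only step between two groups without it, a 1.3-fold lower number from compound 2 to compound 3 (0.10 log units; within the scatter), lies within the scatter. Compound 4 is therefore expected to show a small step, a 1.4-fold higher number from compound 3 to compound 4 (0.14 log units; within the scatter), not beyond the scatter. For compound 4 the estimate in this assay is 50000 nM, expected between 15000 nM and 200000 nM.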

Compound 4, solubility: 217000 nM
Compound 4: the middle estimate sits 4.3-fold (0.64 log units) below what was measured; the measured number lies above the stated range.
By their numbers in this assay, from the lowest: compounds 3 and 2 (each within the scatter of the next); then compound 4; then compound 1.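

In this assay, the place on a saturated chain carbon bound to a saturated ring carbon now separates groups that lack 4-methylpiperazin-1-yl: formylamino in place of methoxy gives a step beyond the scatter (a 6.0-fold higher number from compound 3 to compound 4 (0.78 log units; beyond the scatter)), as does formylamino in place of 2,5-dioxopyrrolidin-1-yl (a 4.8-fold higher number from compound 2 to compound 4 (0.68 log units; beyond the scatter)). The 4-methylpiperazin-1-yl group still stays ahead of formylamino (a 7.8-fold lower number from compound 1 to compound 4 (0.89 log units; beyond the scatter)). Nothing measured here explains the formylamino result.

Going by these compounds, whether a primary amine, an acetylamino group or a carboxylic acid at this place would fall with formylamino or with 4-methylpiperazin-1-yl remains open.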